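The compounds below may be only part of what the source reports. "The series", "measured", "known", "first", "only" and "open" are said of these compounds alone.

Of the compounds shown here, three built on one shared core have been measured in a functional assay on MCF7 cells (Homo sapiens) for cytotoxicity, read by MTT assay, with a stated time of 72 h; on this read-out lower numbers stand for stronger inhibition and higher numbers for weaker inhibition. Compound 1 `CN1[C@@H]2c3[nH]c4ccccc4c3C[C@H]1[C@H](C#N)N1[C@@H](CNC(=O)c3ccc(Cl)cc3)c3[nH]c4ccccc4c3C[C@@H]21` gives 610 nM in this assay, compound 2 `CN1[C@@H]2c3[nH]c4ccccc4c3C[C@H]1[C@H](C#N)N1[C@@H](CNC(=O)c3ccc(F)cc3)c3[nH]c4ccccc4c3C[C@@H]21` gives 980 nM, and compound 3 `CN1[C@@H]2c3[nH]c4ccccc4c3C[C@H]1[C@H](C#N)N1[C@@H](CNC(=O)c3ccc4ccccc4c3)c3[nH]c4ccccc4c3C[C@@H]21` gives 4650 nM, the highest of the three numbers. The two steps that arrive at compound 3 are a 7.6-fold higher number from compound 1 to compound 3 (0.88 log units; beyond the scatter) and a 4.7-fold higher number from compound 2 to compound 3 (0.68 log units; beyond the scatter). Compound 4 `CN1[C@@H]2c3[nH]c4ccccc4c3C[C@H]1[C@H](C#N)N1[C@@H](CNC(=O)/C=C/c3ccccc3)c3[nH]c4ccccc4c3C[C@@H]21` differs from compound 3 by 2-phenylethenyl in place of naphthalen-2-yl on a carbonyl carbon. No measured step covers this exchange; the two steps shown tell only that compound 3, which carries naphthalen-2-yl, stands highest. Swapping that group for 2-phenylethenyl is expected to bring the number partway back toward compound 1 and compound 2, so for compound 4 the expected step is a 2.3-fold lower number from compound 3 to compound 4 (0.37 log units; beyond the scatter). The estimate for compound 4 is 2000 nM, within a range from 700 nM to 6000 nM.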

Compound 4, half-maximal inhibitory concentration: 7190 nM
Compound 4: middle estimate off by 3.6-fold (0.56 log units), on the low side; measured number outside the range, above it.
By their numbers in this assay, from the lowest: compounds 1 and 2 (each within the scatter of the next); then compounds 3 and 4 (each within the scatter of the next).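

In this assay, 2-phenylethenyl in place of naphthalen-2-yl on the carbonyl carbon gives a 1.5-fold higher number from compound 3 to compound 4 (0.19 log units; within the scatter), so these two groups cannot be told apart here, although one has two aromatic rings and the other has one ring plus a double bond. Against the halogen-bearing groups, the same group gives a 7.3-fold higher number from compound 2 to compound 4 (0.87 log units; beyond the scatter) and a 12-fold higher number from compound 1 to compound 4 (1.07 log units; beyond the scatter), so the low numbers here belong only to 4-fluorophenyl and 4-chlorophenyl. Nothing available explains this gap. The compounds shown leave open how a plain phenyl group, a 4-aminophenyl group or a saturated 2-phenylethyl chain would stand at this carbonyl carbon.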